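Dichloro substitution on the pendant phenyl of compound 2

This account rests on a few compounds, and the source may have more. Where it says the series, first, only, none or still open, it means among the compounds named here.

Of the compounds shown here, three sharing the same lactone-bearing core have been measured in an assay for inhibition of 3-hydroxy-3-methylglutaryl-coenzyme A reductase (Rattus norvegicus); on this read-out higher numbers stand for weaker inhibition and lower numbers for stronger inhibition. Compound 1 `Cc1cc(-c2cc(Cl)cc(C)c2/C=C/[C@@H]2C[C@@H](O)CC(=O)O2)ccc1F` gives 6 nM and compound 3 `Cc1cc(-c2cccc(Cl)c2/C=C/[C@@H]2C[C@@H](O)CC(=O)O2)ccc1F` gives 30 nM, while compound 2 `O=C1C[C@H](O)C[C@@H](/C=C/c2c(Cl)cc(Cl)cc2-c2ccccc2)O1` gives 80 nM. Compound 2 therefore stands highest of the three numbers; the gap to compound 3 is beyond the scatter, and the gap to compound 1 is wider still. Compounds 1 and 3 differ from compound 2 in more than one place, so their lower numbers cannot be tied to any single change.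

Compound 4 `O=C1C[C@H](O)C[C@@H](/C=C/c2c(Cl)cc(Cl)cc2-c2cc(Cl)cc(Cl)c2)O1` differs from compound 2 in one place only: 3,5-dichlorophenyl in place of phenyl on an aromatic carbon. Among the measured compounds shown here, no measured pair that differs in one place is available, so the size of this step cannot be read from a precedent. What can be said is that every compound carrying a substituted ring at this position sits lower than compound 2, though each of those also differs elsewhere.

The expectation is a moderate downward step from compound 2 to compound 4 a 2.0-fold lower number from compound 2 to compound 4 (0.30 log units; within the scatter), beyond the scatter but short of the distance to compound 1. Compound 4 is estimated at 40 nM in this assay, with a range from 15 nM to 120 nM.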

Compound 4, half-maximal inhibitory concentration: 37 nM
For compound 4 the middle estimate is 1.1-fold (0.03 log units) above the measured one; the measured number falls inside the stated range.
By their numbers in this assay, from the lowest: compound 1; then compounds 3 and 4 (each within the scatter of the next); then compound 2.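

Among the compounds shown here, this is the first pair that differs in one place, and in this assay it isolates the ring on this aromatic carbon, ortho to a large group: 3,5-dichlorophenyl in place of phenyl gives a 2.2-fold lower number from compound 2 to compound 4 (0.33 log units; beyond the scatter) and is the only change. The step is modest but beyond the scatter, so the lower number of compound 4 can be tied to this one change, which the lower numbers of compounds 1 and 3 could not be. Both groups are six-membered aromatic rings of carbon only, with no hydrogen-bond donors or acceptors and no net charge, so in terms of what is counted here the change amounts to the two added chlorine atoms, and nothing measured here explains the size of the step.

On these data alone, whether one chlorine alone would give the same step remains open, as does the outcome with an amine or a carboxylic acid on this ring. The contribution of the substituted ring in compounds 1 and 3 also cannot be read, as both differ from compound 2 and compound 4 in more than one place.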